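The source may hold more compounds than are shown below. What is called first, only, known or untested is meant among the compounds shown, and "the series" means these compounds.

Measured compounds in a functional assay on Raji cells (Homo sapiens) for antiproliferative activity, read by CCK-8 assay, with a stated time of 72 h, tested at 40 uM; a lower number here means less inhibition, a higher number more inhibition at the concentration tested (going by the name of the read-out):
- compound 1 `CCOC(=O)c1sc(-c2cccc(NC(=O)c3ccccc3)c2)nc1Nc1ccc(N2CCN(C)CC2)cc1`, compound 1 gives 42%
- compound 2 `CCOC(=O)c1sc(-c2cccc(NC(=O)c3ccccc3F)c2)nc1Nc1ccc(N2CCN(C)CC2)cc1`, compound 2 gives 89.8%
- compound 3 `CN1CCN(c2ccc(Nc3nc(-c4cccc(NC(=O)c5ccccc5)c4)sc3C(=O)O)cc2)CC1`, compound 3 gives 11.9%

Compound 3 stands lowest of the three numbers in this assay; its nearest neighbour is compound 1, a number 30.1 percentage points lower from compound 1 to compound 3 (beyond the scatter), and compound 2 lies furthest from it. Compound 3 carries the free acid where compound 1 carries the ethyl ester; the step from ester to acid on the shared core, hydrogen in place of ethyl on an oxygen next to a carbonyl group, cost a large amount of inhibition.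

The next compound, compound 4 `CN1CCN(c2ccc(Nc3nc(-c4cccc(NC(=O)c5ccccc5F)c4)sc3C(=O)O)cc2)CC1`, is not yet measured. It differs from compound 3 in one place: fluoro in place of hydrogen on an aromatic carbon. Cut one bond further out, the same difference reads benzamido to ((2-fluorophenyl)carbonyl)amino.

Going by the values given here, one measured step bears on it directly: a number 47.8 percentage points higher from compound 1 to compound 2 (beyond the scatter), the same fluoro for hydrogen change made on the ethyl ester. Among the compounds with values here, whether that gain carries over fully onto the acid is untested, since no acid pair with this change has been measured. A large upward step is nevertheless expected, of about a number 38.1 percentage points higher from compound 3 to compound 4 (beyond the scatter).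

Compound 4 is therefore estimated at 50% in this assay, with a range from 20% to 85%.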

Compound 4, a percentage reported as inhibition, at one concentration (the size of the read-out at that concentration, not a potency): 86.9%
Estimate against measurement, compound 4: 36.9 percentage points below, and the stated range ends below it.
By their numbers in this assay, from the lowest: compound 3; then compound 1; then compounds 4 and 2 (each within the scatter of the next).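

In this assay, fluoro in place of hydrogen on this aromatic carbon, ortho to a large group, gives a number 75 percentage points higher from compound 3 to compound 4 (beyond the scatter), so the size of the change depends on whether the core carries the free acid or the ethyl ester: the same change on two cores in this assay, a number 47.8 percentage points higher (beyond the scatter) from compound 1 to compound 2 and a number 75 percentage points higher (beyond the scatter) from compound 3 to compound 4, 27.2 percentage points apart, beyond the scatter of two such steps. With the 2-fluorophenyl group in place, going from ester to acid gives a number 2.9 percentage points lower from compound 2 to compound 4 (within the scatter), so the earlier loss on this step does not appear on the fluoro pair: the same change on two cores in this assay, a number 30.1 percentage points lower (beyond the scatter) from compound 1 to compound 3 and a number 2.9 percentage points lower (within the scatter) from compound 2 to compound 4, 27.2 percentage points apart, beyond the scatter of two such steps. The two changes therefore do not add up independently among these four compounds, and the loss of inhibition on going to the acid appears only in the benzamido pair, compound 1 and compound 3.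

Still open, going by these compounds, is whether chloro or methoxy at this place, or fluoro on another carbon of the ring, would also remove the difference between ester and acid. Readings at one concentration in this assay also leave open whether compound 2 and compound 4 would separate in a full concentration-response comparison.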